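A few compounds are considered here, and "the series" means these few. Any claim that something is new, unique, unknown or untested is made for them only; others in the source may bear on it.

Measured so far:
compound 1 `COCCOC(=O)c1c(-c2ccc(OC)c(OC)c2)csc1N`: 57%
compound 2 `CCNC(=O)c1c(-c2ccc(OC)c(OC)c2)csc1N`: 50%

In an assay on isolated protein for inhibition of protein kinase C zeta type (Homo sapiens), with stated times of 1 h and 2.5 min, tested at 30 uM (a lower number here means less inhibition, a higher number more inhibition at the concentration tested (going by the name of the read-out)), compound 1 gives 57%, and compound 2 gives 50%. For the measured compounds named here, the single measured step, a number 7 percentage points lower from compound 1 to compound 2 (within the scatter), exchanged 2-methoxyethoxy for ethylamino on the carbonyl carbon of the shared core. Going by the values given here, compound 2 stands as the lower of the two numbers, with compound 1 its only neighbour and within the scatter of it, so nothing in the two values separates them.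

Compound 3 `COCCNC(=O)c1c(-c2ccc(OC)c(OC)c2)csc1N` has not yet been measured. It differs from compound 2 by methoxy in place of hydrogen on a saturated chain carbon, two bonds along the chain from an amide-type nitrogen. This restores a methoxy group on the chain, which compound 1 carried in its 2-methoxyethoxy group, while the (2-methoxyethyl)amino group retains the amide-type nitrogen of compound 2. Among the compounds with values here, the only step that bears on this, a number 7 percentage points lower from compound 1 to compound 2 (within the scatter), was within the scatter, and no step beyond the scatter is therefore expected: a number 3 percentage points higher from compound 2 to compound 3 (within the scatter). Compound 3 is estimated at 53%, with a range from 36% to 70%.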

Compound 3, a percentage reported as inhibition, at one concentration (the size of the read-out at that concentration, not a potency): 55%
For compound 3 the middle estimate is 2 percentage points below the measured one; measured number inside the range.
By their numbers in this assay, from the lowest: compounds 2, 3 and 1 (each within the scatter of the next).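

In this assay the addition of methoxy on the saturated chain carbon, two bonds along the chain from the amide-type nitrogen, gives a number 5 percentage points higher from compound 2 to compound 3 (within the scatter) and so shows that this position accepts the methoxy group with no step beyond the scatter. With the methoxy group kept on the chain, the exchange of 2-methoxyethoxy for (2-methoxyethyl)amino on the carbonyl carbon gives a number 2 percentage points lower from compound 1 to compound 3 (within the scatter) and is also within the scatter, so this matched pair shows no separation between the two linkages. No supporting data are available to explain these results.

The compounds shown leave open whether a longer chain, a terminal amine or a carboxylic acid at this position would give a step beyond the scatter. From the compounds shown here alone, their potency also remains open, since these percentages each come from a single concentration.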